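A few compounds are considered here, and "the series" means these few. Any claim that something is new, unique, unknown or untested is made for them only; others in the source may bear on it.

Within the data shown here, in an assay for inhibition of Amine oxidase [flavin-containing] A (Rattus norvegicus) (a higher number here means a weaker inhibitor, a lower number a stronger inhibitor), compound 3 `Cc1ccc(COc2ccc(-c3nn(CCC#N)c(=S)o3)cc2)cc1` gives 10000 nM, the second highest of the three numbers measured so far. Its nearest neighbour is compound 2 `Cc1cccc(COc2ccc(-c3nn(CCC#N)c(=S)o3)cc2)c1`, which gives 14000 nM; the step of a 1.4-fold lower number from compound 2 to compound 3 (0.15 log units; within the scatter). Further away lies compound 1 `COc1ccc(COc2ccc(-c3nn(CCC#N)c(=S)o3)cc2)cc1`, which gives 4800 nM; the step of a 2.1-fold higher number from compound 1 to compound 3 (0.32 log units; beyond the scatter). Compound 4 `N#CCCn1nc(-c2ccc(OCc3cccc(Cl)c3)cc2)oc1=S` differs from compound 3 in one place: 3-chlorophenyl in place of 4-methylphenyl on a saturated chain carbon bound to an oxygen on an aromatic ring. Among the measured compounds shown here, two measured steps bear on this change. The step of a 1.4-fold lower number from compound 2 to compound 3 (0.15 log units; within the scatter) shows that shifting a methyl between the two positions on that ring hardly mattered. The step of a 2.9-fold higher number from compound 1 to compound 2 (0.46 log units; beyond the scatter) shows a modest move when methoxy was swapped for methyl. For the measured compounds named here, no chlorine-bearing compound has been measured, so the expected step of a 1.1-fold lower number from compound 3 to compound 4 (0.05 log units; within the scatter) is small. Compound 4 is estimated at 9000 nM, between 4000 nM and 20000 nM.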

Compound 4, half-maximal inhibitory concentration: 11000 nM
Estimate against measurement, compound 4: 1.2-fold (0.09 log units) below; the measured number falls inside the stated range.
By their numbers in this assay, from the lowest: compound 1; then compounds 3, 4 and 2 (each within the scatter of the next).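

In this assay, a chlorine now sits on the ring at this place, and 3-chlorophenyl reads the same as 4-methylphenyl (a 1.1-fold higher number from compound 3 to compound 4 (0.04 log units; within the scatter)) and the same as chloro swapped for the methyl of compound 2 (a 1.3-fold lower number from compound 2 to compound 4 (0.10 log units; within the scatter)). The 4-methoxyphenyl of compound 1 remains the one ring that stands apart (a 2.3-fold higher number from compound 1 to compound 4 (0.36 log units; beyond the scatter)). Nothing measured here explains why these rings read alike. Still open, from the compounds shown here alone, is whether an amine or a carboxylic acid on this ring, or a longer chain linking it to the oxygen, would move the number.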